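The compounds below may be only part of what the source reports. "The series", "measured", "known", "first", "only" and "open" are said of these compounds alone.

Working notes on the series.

Compound 3 `CCc1cc(C(C)=O)c(O)cc1OCCCCCCCC(C)(C)C#N` stands lowest of the three compounds measured in an assay on isolated protein for binding affinity to leukotriene B4 receptor 1 (Homo sapiens), tested at 1 uM (on this read-out higher numbers stand for more inhibition at the one concentration tested (going by the name of the read-out) and lower numbers for less inhibition), giving 29%. Compound 2 `CCc1cc(C(C)=O)c(O)cc1OCCCCCC(C)(C)C#N` gives 53% and compound 1 `CCc1cc(C(C)=O)c(O)cc1OCCCCC#N` gives 57%; the two of them sit within the scatter of each other, as a number 4 percentage points lower from compound 1 to compound 2 (within the scatter) shows, whereas a number 28 percentage points lower from compound 1 to compound 3 (beyond the scatter) and a number 24 percentage points lower from compound 2 to compound 3 (beyond the scatter) both lie beyond it.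

The next compound, compound 4 `CCc1cc(C(C)=O)c(O)cc1OCCCCCC(C)(C)c1nnnn1C`, differs from compound 3 in one place: 1-methyl-1-(1-methyl-1H-tetrazol-5-yl)ethyl in place of 3-cyano-3-methylbutyl on a saturated chain carbon, five bonds along the chain from an oxygen on an aromatic ring. For the measured compounds named here, no measured step swaps a nitrile for a ring, so none bears on the new group directly. The steps that do bear on it are those that alter what hangs on the same chain carbon, five bonds along from the oxygen: a number 24 percentage points lower from compound 2 to compound 3 (beyond the scatter) and a number 28 percentage points lower from compound 1 to compound 3 (beyond the scatter), both modest losses on lengthening the chain. From the compounds shown here alone, compound 4 carries its terminal group on a chain of the length seen in compound 2 rather than compound 3, so the expectation for this assay is a modest step upward, a number 16 percentage points higher from compound 3 to compound 4 (beyond the scatter), though the ring itself is untested and the range must be wide. Compound 4 is therefore estimated at 45%, between 20% and 70%.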

Compound 4, a percentage reported as inhibition, at one concentration (the size of the read-out at that concentration, not a potency): 59%
Estimate against measurement, compound 4: 14 percentage points below; low and high end bracket the measured number.
By their numbers in this assay, from the lowest: compound 3; then compounds 2, 1 and 4 (each within the scatter of the next).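

The tetrazole ring is the new feature here, and in this assay the replacement of the nitrile by 1-methyl-1H-tetrazol-5-yl on a saturated chain carbon bound to three saturated chain carbons gives a number 6 percentage points higher from compound 2 to compound 4 (within the scatter), so this read-out does not separate the two groups at this position. The larger change, a number 30 percentage points higher from compound 3 to compound 4 (beyond the scatter), replaces 3-cyano-3-methylbutyl with 1-methyl-1-(1-methyl-1H-tetrazol-5-yl)ethyl and so alters both the chain and the terminal group, which means it cannot be credited to the ring alone. No measurement shown here explains why the ring and the nitrile read alike at this position.

The compounds shown leave open whether 1-methyl-1H-tetrazol-5-yl, carried on the chain of 3-cyano-3-methylbutyl, would give the low reading seen for the nitrile in compound 3, and whether a carboxylic acid or a primary amide on the same saturated chain carbon would read like the nitrile and the ring. Readings at a single concentration also leave open how the potencies of these compounds compare.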